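Swapping a diene side chain for an enone on a coumarin-free-named core

This account rests on a few compounds, and the source may have more. Where it says the series, first, only, none or still open, it means among the compounds named here.

Measured so far in a functional assay on BV-2 cells (Mus musculus) for inhibition, read by Griess assay, with a stated time of 24 h; on this read-out lower numbers stand for stronger inhibition and higher numbers for weaker inhibition:
- compound 1, `C=C(C)/C=C/c1c(OC)ccc2ccc(=O)oc12`: 11800 nM
- compound 2, `C=C(C)[C@H](O)[C@H](OC(=O)CC(C)C)c1c(OC)ccc2ccc(=O)oc12`: 26400 nM

Both compounds share one core, on which a side chain sits on an aromatic carbon. Compound 1 carries a 3-methylbuta-1,3-dien-1-yl chain and gives the lowest of the two numbers in this assay. Compound 2, whose chain carries oxygen groups, gives a higher number, and the gap between compound 1 and compound 2 lies beyond the usual scatter of repeated measurements.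

Compound 3, `COc1ccc2ccc(=O)oc2c1/C=C\C(C)=O`, has not yet been measured. It differs from compound 1 in one place: a group of 5 heavy atoms (4 carbon, 1 oxygen; no ring) in place of a group of 5 heavy atoms (5 carbon; no ring), on an aromatic carbon. For the measured compounds named here, no pair of measured compounds shows this same change, so there is no measured step to lean on; the only hint is that the oxygen-bearing chain of compound 2 goes with a weaker result than compound 1.

The step from compound 1 to compound 3 is therefore expected to be small, most likely within the scatter or slightly toward a weaker result: a 1.3-fold higher number from compound 1 to compound 3 (0.10 log units; within the scatter). For compound 3 the expected value in this assay is 15000 nM, with a plausible range from 5000 nM to 45000 nM.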

Compound 3, half-maximal inhibitory concentration: 16900 nM
For compound 3 the middle estimate is 1.1-fold (0.05 log units) below the measured one; the measured number falls inside the stated range.
By their numbers in this assay, from the lowest: compounds 1, 3 and 2 (each within the scatter of the next, the first and the last beyond it).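

In this assay the change of the 3-methylbuta-1,3-dien-1-yl chain for a chain of the same size that carries a carbonyl gives a 1.4-fold higher number from compound 1 to compound 3 (0.16 log units; within the scatter) and so stays within the usual scatter of repeated measurements. At this aromatic carbon, ortho to a methoxy group, one oxygen entering the chain and bringing one hydrogen-bond acceptor is therefore not enough on its own to move the number measurably, and this single step gives no sign that a chain with oxygen must do worse here than the all-carbon chain. The data shown offer nothing that could explain this outcome.

On these data alone, what happens with a larger change at this position remains open, for example a longer chain, an amine or a carboxylic acid in place of the side chain, any of which might move the number beyond the scatter. Also open is whether the small size of this step holds for the same exchange at any other place on the shared core, since only this one position is covered by the compounds shown.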